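The source may hold more compounds than are shown below. What is called first, only, known or untested is meant among the compounds shown, and "the series" means these compounds.

Measured compounds:
Compound 1, `Cc1ncc([N+](=O)[O-])n1CCCCCBr`: 83 ug/mL.
Compound 2, `Cc1ncc([N+](=O)[O-])n1CCCCN1CCCCC1`: > 100 ug/mL, a limit.
Compound 3, `Cc1ncc([N+](=O)[O-])n1CCCCCN1CCCCC1`: > 100 ug/mL, a limit.

Among the measured compounds shown here, in an ADME assay on J774 cells (Mus musculus) for cytotoxicity, read by resazurin assay, with a stated time of 24 h (on this read-out higher numbers stand for weaker inhibition and lower numbers for stronger inhibition), compound 1 is the only compound with a number; the other two sit at the limit of > 100 ug/mL in this assay, at which 2 of the 3 values shown sit. Compound 4, `Cc1ncc([N+](=O)[O-])n1CCCN1CCCC1`, differs from compound 1 by pyrrolidin-1-yl in place of 2-bromoethyl on a saturated chain carbon, three bonds along the chain from an aromatic nitrogen. For the measured compounds named here, two measured steps bear on this, each also swapping a bromine-bearing end of the chain for a cyclic amine: an at least 1.2-fold higher number from compound 1 to compound 2 (0.08 log units; that floor lies within the scatter) and an at least 1.2-fold higher number from compound 1 to compound 3 (0.08 log units; that floor lies within the scatter). Both floors lie within the scatter, so only a move toward weaker inhibition, of uncertain size, can be read from them. Compound 4 is therefore expected to give about 120 ug/mL, between 55 ug/mL and 300 ug/mL. The step expected is a 1.4-fold higher number from compound 1 to compound 4 (0.16 log units; within the scatter).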

Compound 4, half-maximal inhibitory concentration: > 100 ug/mL
Compound 4: no number, only a limit; the forecaster's own chance of this, stated with the estimate: 60%; the middle value does not contradict the limit.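

In this assay, compound 4 gives only a limit, > 100 ug/mL, and not a number. From the compounds shown here alone, replacing 2-bromoethyl with pyrrolidin-1-yl gives an at least 1.2-fold higher number from compound 1 to compound 4 (0.08 log units; that floor lies within the scatter), so the true size of the change stays unknown. A five-membered ring amine, three bonds along the chain, now joins the piperidin-1-yl compounds 2 and 3 at the limit, leaving the bromine-bearing compound 1 as the only one with a number: the limit of > 100 ug/mL in this assay, at which 3 of the 4 values shown sit.

Still open, going by these compounds, is how large these steps really are. An open-chain amine such as diethylamino, or a carboxylic acid at the chain end, might behave differently.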